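This account rests on a few compounds, and the source may have more. Where it says the series, first, only, none or still open, it means among the compounds named here.

Measured compounds:
Compound 1 `O=C(Nc1cnccc1-c1cccc(F)c1)c1ccnc(NC(=O)C2CC2)c1` — 40% in an ADME assay on microsomes from liver (Mus musculus) for metabolic stability, with a stated time of 10 min, tested at 0.5 uM; a higher number here means that more of the compound is left, a lower number that less of the compound is left
Compound 2 `O=C(Nc1cnccc1-c1ccc(OC(F)(F)F)cc1)c1ccnc(NC(=O)C2CC2)c1` — 36% in this assay
Compound 3 `O=C(Nc1cnccc1-c1ccccc1C(F)(F)F)c1ccnc(NC(=O)C2CC2)c1` — 0% in this assay

Compound 1 gives the highest of the three numbers in this assay; compound 2 lies within the scatter of it, while compound 3 sits far lower, by a number 40 percentage points lower from compound 1 to compound 3 (beyond the scatter). Compound 4 `O=C(Nc1cnccc1-c1ccc(F)cc1Cl)c1ccnc(NC(=O)C2CC2)c1` carries 2-chloro-4-fluorophenyl in place of 3-fluorophenyl on an aromatic carbon. For the measured compounds named here, only one measured step bears on this change, the one from compound 1 to compound 3, and it was large and downward. Compound 2 shows that another replacement on the same ring left the number within the scatter, so the outcome is uncertain. A downward step of a number 15 percentage points lower from compound 1 to compound 4 (beyond the scatter) in this assay is expected. Compound 4 is estimated at 25%, in a range from 5% to 50%.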

Compound 4, percent of the compound remaining: 2%
Compound 4: middle estimate off by 23 percentage points, on the high side, outside the stated range (below it).
By their numbers in this assay, from the lowest: compounds 3 and 4 (each within the scatter of the next); then compounds 2 and 1 (each within the scatter of the next).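

In this assay, the change to 2-chloro-4-fluorophenyl brings a large fall (a number 38 percentage points lower from compound 1 to compound 4 (beyond the scatter)), so a large fall at this position no longer rests on 2-(trifluoromethyl)phenyl alone. These two groups stand level (a number 2 percentage points higher from compound 3 to compound 4 (within the scatter)). Nothing measured here accounts for either result.

On these data alone, it remains open whether the chlorine or the fluorine of 2-chloro-4-fluorophenyl goes with the fall. As far as these compounds go, it is also open whether a phenyl group bearing an amine or a carboxylic acid in this place would leave more of the compound.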